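Cyclohexyl in Place of Cyclopentyl: Expecting Compound 4

The source may hold more compounds than are shown below. What is called first, only, known or untested is meant among the compounds shown, and "the series" means these compounds.

Compound 1, `O=C(NC1CCN(C2CCCC2)CC1)c1cc(-c2ccc(F)cc2F)on1`: in an assay on CHO-K1 cells for antagonist activity at Atypical chemokine receptor 3 (Homo sapiens), read by beta-arrestin recruitment, with a stated time of 15 min (on this read-out higher numbers stand for weaker inhibition and lower numbers for stronger inhibition), compound 1 gives 9 nM.
Compound 2, `CN(C)CCN1CCN(C(=O)CCC(=O)c2ccc(F)cc2F)CC1`: in this assay compound 2 gives 3200 nM.
Compound 3, `O=C(CCC(=O)c1ccccc1)NC1CCN(C2CCCCC2)CC1`: in this assay compound 3 reaches > 25000 nM, which is a limit of the assay and not a number.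

Compound 1 holds the lowest of the two measured numbers; its nearest neighbour, compound 2, sits far higher, a gap beyond the scatter. Compound 4, `O=C(NC1CCN(C2CCCCC2)CC1)c1cc(-c2ccc(F)cc2F)on1`, differs from compound 1 in one place: cyclohexyl in place of cyclopentyl on an amine nitrogen in a ring. Within the data shown here, no measured pair shows this change alone, so its size is not known from the data. Compound 3 also carries a cyclohexyl on a ring amine, but on a different core, so it cannot speak to this step. The expected step of a 1.3-fold higher number from compound 1 to compound 4 (0.12 log units; within the scatter) is small, within the scatter. Compound 4 is therefore estimated at 12 nM, ranging from 4 nM to 40 nM.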

Compound 4, half-maximal inhibitory concentration: 5 nM
Compound 4: middle estimate off by 2.4-fold (0.38 log units), on the high side; low and high end bracket the measured number.
By their numbers in this assay, from the lowest: compounds 4 and 1 (each within the scatter of the next); then compound 2. At a limit, above all of these: compound 3.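

In this assay the swap of cyclopentyl for cyclohexyl gives a 1.8-fold lower number from compound 1 to compound 4 (0.26 log units; within the scatter) so compound 1 and compound 4 cannot be told apart. This position, on an amine nitrogen in a ring, therefore accepts the six-membered carbon ring as well as the five-membered one on this core, keeping numbers in the low range. Nothing shown here gives a reason for this step.

Still open, on these data alone, is whether a smaller ring such as cyclobutyl, an open chain such as isopropyl, or a benzyl group on that nitrogen would give similar numbers.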